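The compounds below may be only part of what the source reports. "The series", "measured", "known", "first", "only" and "open" are said of these compounds alone.

Compound 1 `Oc1ccc(-c2cc(-c3cccnc3)nc(-c3ccccc3Cl)c2)cc1`: "not determined" (no result reported). Compound 2 `Oc1cccc(-c2cc(-c3ccc(Cl)cc3)nc(-c3cccs3)c2)c1`: 9280 nM.

Going by the values given here, in a functional assay on HCT-15 cells (Homo sapiens) for cytotoxicity, read by CCK-8 assay and cell counting, with a stated time of 2 days (on this read-out lower numbers stand for stronger inhibition and higher numbers for weaker inhibition), compound 2 gives 9280 nM, the only number obtained, since compound 1 returned "not determined" (no result reported). Compound 3 `Oc1cccc(-c2cc(-c3ccc(Cl)cc3)nc(-c3ccco3)c2)c1` differs from compound 2 by furan-2-yl in place of thiophen-2-yl on an aromatic carbon. Among the compounds with values here, no step between two measured compounds exists here to show how such an exchange acts, so the expected step is a 1.1-fold higher number from compound 2 to compound 3 (0.03 log units; within the scatter), not beyond the usual scatter, in no clear direction. Compound 3 is therefore estimated at 10000 nM in this assay, with a range from 4000 nM to 25000 nM.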

Compound 3, half-maximal inhibitory concentration: 10200 nM
Compound 3: middle estimate off by 1.0-fold (0.01 log units), on the low side, within the range that was stated.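

In this assay, going by these compounds alone, the step of a 1.1-fold higher number from compound 2 to compound 3 (0.04 log units; within the scatter) gives the first reading at this position, on the aromatic carbon next to the ring nitrogen. On this read-out, furan-2-yl and thiophen-2-yl cannot be told apart here, so an oxygen in place of the sulfur of this five-membered aromatic ring leaves no effect that can be read. No measurement shown accounts for this result. The compounds shown leave open whether a group of another kind at this position, such as an amine or a carboxylic acid, would move the number beyond the scatter.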